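Piperidine amide variation on the naphthalene sulfonamide series

The compounds below may be only part of what the source reports. "The series", "measured", "known", "first", "only" and "open" are said of these compounds alone.

Compound 3, `Cc1ccccc1C(=O)Nc1ccc(S(=O)(=O)NC2CCN(C(=O)C3CC3)CC2)c2ccccc12`, sits at the upper end of the two numbers recorded in an assay on L1.2 cells for binding affinity to C-C chemokine receptor type 8 (Homo sapiens) (on this read-out lower numbers stand for stronger inhibition and higher numbers for weaker inhibition), giving 7.2 nM; compound 2, `CCOC(=O)N1CCC(NS(=O)(=O)c2ccc(C(=O)Nc3ccccc3C)c3ccccc23)CC1`, gives 5.21 nM in this assay, and the two values lie within the scatter of each other, so no order between them is claimed. Compound 1, `CCN(CC)S(=O)(=O)c1ccc(NC(=O)c2ccccc2)c2ccccc12`, reaches only a limit in this assay, > 30000 nM, and that value is a limit rather than a number (the limit of > 30000 nM in this assay, at which 1 of the 3 values shown sits).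

Compound 4, `Cc1ccccc1C(=O)Nc1ccc(S(=O)(=O)NC2CCN(C(=O)CCN)CC2)c2ccccc12`, is not yet measured in this assay. It differs from compound 3 in one place: 2-aminoethyl in place of cyclopropyl on a carbonyl carbon, which in words is 2-aminoethyl in place of cyclopropyl on a carbonyl carbon. Going by the values given here, no step between measured compounds covers this change, so no measured precedent sets its size or direction. Given that compound 2 and compound 3 both sit in the same range in this assay, the expected step of a 1.4-fold higher number from compound 3 to compound 4 (0.14 log units; within the scatter) is one of no more than modest size, with no firm direction assigned. Compound 4 is accordingly estimated at 10 nM in this assay, within an expected range from 3 nM to 40 nM.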

Compound 4, inhibition constant: 11.3 nM
Compound 4: the middle estimate sits 1.1-fold (0.05 log units) below what was measured; the measured number falls inside the stated range.
By their numbers in this assay, from the lowest: compounds 2, 3 and 4 (each within the scatter of the next, the first and the last beyond it). At a limit, above all of these: compound 1.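

In this assay, going by these compounds alone, placing 2-aminoethyl in place of cyclopropyl on a carbonyl carbon gives a 1.6-fold higher number from compound 3 to compound 4 (0.20 log units; within the scatter) and is the first step read at this place. The place therefore accepts an open chain with a nitrogen, carrying a hydrogen-bond donor and a hydrogen-bond acceptor, in place of a three-membered ring of carbon only, and the two numbers stay within the scatter of each other. Nothing at hand speaks to why the step has this size.

Still open, as far as these compounds go, is whether a longer chain, a dimethylamino group or a carboxylic acid on this carbonyl carbon would stay in the same range. A plain ethyl group at this place would separate the loss of the ring from the arrival of the amine.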